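A sulfonylethyl chain replaces the oxadiazolylmethoxy group

This account rests on a few compounds, and the source may have more. Where it says the series, first, only, none or still open, it means among the compounds named here.

Compound 1 `CCOc1cccc2c1S(=O)(=O)N=C2C1=C(O)[C@H](C(C)(C)C)N(CCC(C)(C)C)C1=O` is known in an in vitro ADME assay on microsomes from liver (Homo sapiens) for metabolic stability (a lower number here means that the compound disappears faster, a higher number that the compound lasts longer), only as a limit, and in that test compound 1 gives > 1 h. Compound 2 `CC(C)(C)CCN1C(=O)C(C2=NS(=O)(=O)c3c(OCc4ncon4)cccc32)=C(O)[C@@H]1C(C)(C)C` gives 0.733 h in this assay. Between the two stands an at least 1.3-fold lower number from compound 1 to compound 2 (0.13 log units; that floor lies within the scatter), the change being 1,2,4-oxadiazol-3-yl in place of methyl on a saturated chain carbon bound to an oxygen on an aromatic ring. Among the measured compounds shown here, compound 2 thus holds the only number in this assay; the other value shown is the limit of > 1 h in this assay, at which 1 of the 2 values shown sits. Compound 3 `CC(C)(C)CCN1C(=O)C(C2=NS(=O)(=O)c3c(CCS(C)(=O)=O)cccc32)=C(O)[C@@H]1C(C)(C)C` differs from compound 2 by 2-(methylsulfonyl)ethyl in place of (1,2,4-oxadiazol-3-yl)methoxy on an aromatic carbon. For the measured compounds named here, only one measured step bears on this change, and its floor lies within the scatter, so no shift beyond the scatter is expected for compound 3. For compound 3 a half-life of 0.7 h is expected, within 0.3 h and 1.5 h, which amounts to an expected step of a 1.0-fold lower number from compound 2 to compound 3 (0.02 log units; within the scatter).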

Compound 3, half-life: > 1 h
Compound 3 ended at the assay's limit (the forecaster's own chance of this, stated with the estimate: 30%); middle value at least 1.4-fold (0.15 log units) from the limit.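

The change at this aromatic carbon shows that a chain with no ring, 2-(methylsulfonyl)ethyl, can replace (1,2,4-oxadiazol-3-yl)methoxy and still leave compound 3 at the limit of this assay, as the ethoxy group of compound 1 had done. Across this change the data give an at least 1.3-fold higher number from compound 2 to compound 3 (0.13 log units; that floor lies within the scatter), so no shift beyond the scatter can be claimed, and the true size of the step stays hidden behind the limit. The step between compound 1 and compound 3 cannot be read, and the top of the scale now holds two of the compounds: the limit of > 1 h in this assay, at which 2 of the 3 values shown sit.

From the compounds shown here alone, how long compound 3 actually lasts remains open, and with it any ranking against compound 1. Also open, going by these compounds, is whether an amine or a carboxylic acid at the end of a chain on this aromatic carbon would keep a compound at that limit.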